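Swapping the halogenated heterocycle at the chain end

A few compounds are considered here, and "the series" means these few. Any claim that something is new, unique, unknown or untested is made for them only; others in the source may bear on it.

Measured compounds:
- compound 1, `O=C1NC(O)(/C=C\n2cc(I)c3c(Cl)ncnc32)C(OCc2ccccc2)=C1OCc1ccccc1`, 46900 nM
- compound 2, `O=C1NC(O)(CCn2cnc3ccnc(Cl)c32)C(OCc2ccccc2)=C1OCc1ccccc1`; its result is a limit of the assay, > 100000 nM
- compound 3, `O=C1O/C(=C\Cn2cnc3c(F)nc(F)c(Cl)c32)C(OCc2ccccc2)=C1OCc1ccccc1`, 55000 nM

All three were tested in a functional assay on SW-620 cells (Homo sapiens) for antiproliferative activity, read by MTT assay, with a stated time of 72 h; a lower number here means a stronger inhibitor, a higher number a weaker inhibitor. Compound 3 gives the higher of the two numbers, yet its value and that of compound 1 lie within the scatter of each other, so no order between them can be read. Of compound 2 only the limit is known. the limit of > 100000 nM in this assay, at which 1 of the 3 values shown sits.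

Compound 4, `O=C1O/C(=C\Cn2cnc3cc[nH]c3c2=O)C(OCc2ccccc2)=C1OCc1ccccc1`, carries a different heterocycle on the chain: a group of 10 heavy atoms (6 carbon, 3 nitrogen, 1 oxygen; one five-membered aromatic ring with 1 hetero atom, one six-membered aromatic ring with 2 hetero atoms) in place of a group of 12 heavy atoms (6 carbon, 3 nitrogen, 2 fluorine, 1 chlorine; one five-membered aromatic ring with 2 hetero atoms, one six-membered aromatic ring with 1 hetero atom), on a saturated chain carbon bound to a double-bonded chain carbon. Within the data shown here, no measured step of this kind is available, so the expectation is a step from compound 3 to compound 4 of no more than the scatter, no change at the digits printed from compound 3 to compound 4 (within the scatter). Compound 4 is therefore estimated at 55000 nM, between 18000 nM and 100000 nM.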

Compound 4, half-maximal inhibitory concentration: > 100000 nM
Compound 4 was reported as a limit (the forecaster's own chance of this, stated with the estimate: 35%); middle value at least 1.8-fold (0.25 log units) away from the limit.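

Compound 4 has no fluorine or chlorine in the group on this saturated chain carbon, and its result is a limit of the assay, > 100000 nM. As far as these compounds go, the change gives an at least 1.8-fold higher number from compound 3 to compound 4 (0.25 log units; that floor lies within the scatter), so the swap can be read only as a floor, and the real size of the step stays unknown. Results of this kind now make up a larger share of the set: the limit of > 100000 nM in this assay, at which 2 of the 4 values shown sit.

Still open, from the compounds shown here alone, is whether the fluorine or the chlorine atoms of the leaving group matter for the value. Going by these compounds, how a simple amine on this chain carbon would compare is also open.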